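Microsomal clearance notes: imidazole to pyrazole swap

The source may hold more compounds than are shown below. What is called first, only, known or untested is meant among the compounds shown, and "the series" means these compounds.

For the measured compounds named here, compound 1 `Cc1nccn1-c1cnc(NCc2c(F)ccc3c2CCO3)c2cn[nH]c(=O)c12` has the lower of the two numbers so far in an ADME assay on microsomes from liver (Homo sapiens) for metabolic stability, read by LC-MS, using NADPH, with stated times of 5 min and 30 min, tested at 1 uM (on this read-out higher numbers stand for fast clearance and lower numbers for slow clearance), giving 8 mL.min-1.g-1; compound 2 `CN(C)Cc1ccc(C(=O)Nc2cnc(NCc3c(F)ccc4c3CCO4)n3cnnc23)cc1` gives 13 mL.min-1.g-1 in this assay, a gap that sits within the scatter. Compound 3 `Cc1nn(C)cc1-c1cnc(NCc2c(F)ccc3c2CCO3)c2cn[nH]c(=O)c12` carries the change (1,3-dimethyl-1H-pyrazol-4-yl in place of 2-methyl-1H-imidazol-1-yl on an aromatic carbon). Going by the values given here, no pair differing in a single place has been measured, so the step from compound 1 to compound 3 in this assay is expected to be small, with no clear direction beyond the scatter. Compound 3 is therefore estimated at 10 mL.min-1.g-1 in this assay, with a range of 5 mL.min-1.g-1 to 20 mL.min-1.g-1, the expected step being a 1.3-fold higher number from compound 1 to compound 3 (0.10 log units; within the scatter).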

Compound 3, intrinsic clearance in microsomes: 27 mL.min-1.g-1
Estimate against measurement, compound 3: 2.7-fold (0.43 log units) below; the measured number lies above the stated range.
By their numbers in this assay, from the lowest: compounds 1 and 2 (each within the scatter of the next); then compound 3.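

In the only single-place pair shown, 1,3-dimethyl-1H-pyrazol-4-yl in place of 2-methyl-1H-imidazol-1-yl on this aromatic carbon brings a 3.4-fold higher number from compound 1 to compound 3 (0.53 log units; beyond the scatter) in this assay and so the choice of five-membered ring here registers in clearance. The two groups have the same hydrogen-bond donor and acceptor counts and no net charge, so those counts do not separate them. No measurement at hand accounts for the step.

Open, on these data alone, is whether the step follows the ring itself or its methyl groups. A 1-methyl-1H-pyrazol-4-yl or a morpholine at this carbon would bear on that question.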